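Triazolylsulfanyl in place of acetoxy on the nitrophenyl series

The compounds below may be only part of what the source reports. "The series", "measured", "known", "first", "only" and "open" are said of these compounds alone.

Three compounds have been measured in a functional assay on T47D cells (Homo sapiens) for antiproliferative activity, read by sulforhodamine B assay, with a stated time of 48 h; on this read-out lower numbers stand for stronger inhibition of growth and higher numbers for weaker inhibition of growth:
compound 1 `COc1cc(-c2nc(CO[C@@H]3O[C@H](CSc4ncn[nH]4)[C@H]4OC5(CCCC5)O[C@@H]34)no2)cc(OC)c1OC` gives 44000 nM
compound 2 `Nc1nnc(SC[C@H]2O[C@@H](OCc3noc(-c4ccc([N+](=O)[O-])cc4)n3)[C@@H]3OC4(CCCC4)O[C@@H]32)s1` gives 19000 nM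
compound 3 `CC(=O)OC[C@H]1O[C@@H](OCc2noc(-c3ccc([N+](=O)[O-])cc3)n2)[C@@H]2OC3(CCCC3)O[C@@H]21` gives 52000 nM

Compound 3 has the highest number of the three, although its gap to compound 1 is within the scatter; only compound 2 sits clearly lower. The unmeasured compound 4 `O=[N+]([O-])c1ccc(-c2nc(CO[C@@H]3O[C@H](CSc4ncn[nH]4)[C@H]4OC5(CCCC5)O[C@@H]34)no2)cc1` differs from compound 3 by (1H-1,2,4-triazol-5-yl)sulfanyl in place of acetoxy on a saturated chain carbon bound to a saturated ring carbon. Going by the values given here, the one step that bears on this is a 2.7-fold higher number from compound 2 to compound 3 (0.44 log units; beyond the scatter), which swapped a related sulfanyl-linked azole for the acetoxy group in the opposite direction. Reversing that move on the same nitrophenyl core, compound 4 is expected to show a modest fall in number, a 2.4-fold lower number from compound 3 to compound 4 (0.37 log units; beyond the scatter), in this assay. The estimate for compound 4 is 22000 nM, within 10000 nM to 50000 nM.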

Compound 4, concentration for 50% growth inhibition: 20000 nM
Beside the measured number, compound 4's estimate is 1.1-fold (0.04 log units) above it; low and high end bracket the measured number.
By their numbers in this assay, from the lowest: compounds 2 and 4 (each within the scatter of the next); then compounds 1 and 3 (each within the scatter of the next).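

In this assay, (1H-1,2,4-triazol-5-yl)sulfanyl in place of acetoxy gives a 2.6-fold lower number from compound 3 to compound 4 (0.41 log units; beyond the scatter) on the nitrophenyl series, so a second sulfanyl-linked azole at this place also goes with a lower number. The choice between these two azoles shows no effect here, with a 1.1-fold higher number from compound 2 to compound 4 (0.02 log units; within the scatter) on swapping 5-amino-1,3,4-thiadiazol-2-yl for 1H-1,2,4-triazol-5-yl on the sulfur. With the triazolylsulfanyl group held fixed, the aryl group also counts, with a 2.2-fold lower number from compound 1 to compound 4 (0.34 log units; beyond the scatter) for 4-nitrophenyl in place of 3,4,5-trimethoxyphenyl.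

No evidence is available that explains these steps. As far as these compounds go, whether the azole is needed at all stays open, since a plain methylsulfanyl group or an amine at this place could give a similar number.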